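Ethoxy for Methoxy on a Weak Aorta Inhibitor

The compounds below may be only part of what the source reports. "The series", "measured", "known", "first", "only" and "open" are said of these compounds alone.

Of the compounds shown here, two sharing one core have so far been measured in a functional assay on aorta (strain Wistar) for inhibition, with Thoracic aorta (Rattus norvegicus) as the target; on this read-out lower numbers stand for stronger inhibition and higher numbers for weaker inhibition. Compound 1 `CCOc1nc(-c2cc3ccccc3o2)cc(-c2cccc3ccccc23)c1C#N` carries an ethoxy group and a naphthyl substituent, and in this assay compound 1 gives 344000 nM. Compound 2 `COc1ccc(OC)c(-c2cc(-c3cc4ccccc4o3)nc(OC)c2C#N)c1` instead carries a methoxy group and a dimethoxyphenyl substituent, and in this assay compound 2 gives 246000 nM. The two numbers sit within the usual scatter of each other, so neither compound can be called the stronger inhibitor; both inhibit only weakly. Compound 1 and compound 2 differ in two places at once. The two numbers alone show nothing about either change on its own.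

Compound 3 `CCOc1nc(-c2cc3ccccc3o2)cc(-c2cc(OC)ccc2OC)c1C#N` is the next compound, not yet measured. It keeps the dimethoxyphenyl substituent of compound 2 and changes only one thing: methyl in place of hydrogen on a saturated chain carbon bound to an oxygen on an aromatic ring, that is, methoxy to ethoxy. Among the compounds with values here, no measured pair isolates this change, so there is no step to lean on. Given that compound 1, which already bears an ethoxy group, gives 344000 nM, the expectation is for a step from compound 2 to compound 3 of about a 1.1-fold higher number from compound 2 to compound 3 (0.02 log units; within the scatter), essentially none beyond the scatter. Compound 3 is therefore estimated at 260000 nM, with a likely range from 110000 nM to 620000 nM.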

Compound 3, half-maximal inhibitory concentration: 327000 nM
For compound 3 the middle estimate is 1.3-fold (0.10 log units) below the measured one, within the range that was stated.
By their numbers in this assay, from the lowest: compounds 2, 3 and 1 (each within the scatter of the next).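

With the dimethoxyphenyl substituent held fixed, methoxy to ethoxy now stands alone as a single change, and in this assay the added methyl gives a 1.3-fold higher number from compound 2 to compound 3 (0.12 log units; within the scatter) and so does not move the read-out beyond the scatter at this position. With the ethoxy group held fixed, the other single change, 2,5-dimethoxyphenyl in place of naphthalen-1-yl on an aromatic carbon, gives a 1.1-fold lower number from compound 1 to compound 3 (0.02 log units; within the scatter) and also stays within the scatter, so each of the two changes that were tangled together in the first pair can now be read on its own, and neither shows a measurable effect. Nothing available offers an independent measurement that could explain why these steps are so small.

The compounds shown test only one added methyl on this chain, so it remains open whether a longer chain such as propyl or butyl, or an amine or a carboxylic acid at its end, would shift the number beyond the scatter. As far as these compounds go, it also remains open whether any substituent on the shared core can bring inhibition in this assay far below the values seen so far.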